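The compounds below may be only part of what the source reports. "The series", "measured", "known", "first", "only" and "open" are said of these compounds alone.

Measured compounds:
compound 1 `COc1ccccc1-c1cc(C)c(Nc2ccnc(Nc3ccc(C#N)cc3)n2)c(C)c1`, 940 nM
compound 2 `Cc1cc(-c2ccccc2)cc(C)c1Nc1ccnc(Nc2ccc(C#N)cc2)n1`, 4170 nM

The read-out throughout is an ADME assay on MT4 cells (Homo sapiens) for cytotoxicity, read by MTT assay, with a stated time of 4 days; a lower number here means that less compound is tolerated, a higher number that more compound is tolerated. Within the data shown here, on the two numbers available, compound 2 sits at the top: in this assay compound 2 gives 4170 nM, with compound 1 as its only neighbour, and the measured step there is a 4.4-fold higher number from compound 1 to compound 2 (0.65 log units; beyond the scatter), a change of hydrogen in place of methoxy on an aromatic carbon.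

The unmeasured compound 3 `Cc1cc(-c2ccc(Cl)cc2)cc(C)c1Nc1ccnc(Nc2ccc(C#N)cc2)n1` differs from compound 2 by chloro in place of hydrogen on an aromatic carbon. No measured step involves a chloro group, so the single step from compound 1 to compound 2 bears only loosely on it: it shows that a change at this ring can move the number beyond the scatter, but in which direction a chloro entry would act is not shown. The step is therefore expected to be small, a 1.4-fold lower number from compound 2 to compound 3 (0.14 log units; within the scatter), and compound 3 is estimated at 3000 nM, within the range 1000 nM to 9000 nM.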

Compound 3, half-maximal cytotoxic concentration: 4190 nM
Beside the measured number, compound 3's estimate is 1.4-fold (0.15 log units) below it; low and high end bracket the measured number.
By their numbers in this assay, from the lowest: compound 1; then compounds 2 and 3 (each within the scatter of the next).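

In this assay, putting chloro on the outer ring gives a 1.0-fold higher number from compound 2 to compound 3 (0.00 log units; within the scatter), so compound 2 and compound 3 cannot be told apart, whereas the earlier pair showed only that removing methoxy from this ring could shift the number. Compound 1 remains the one that differs from the others, with a 4.5-fold higher number from compound 1 to compound 3 (0.65 log units; beyond the scatter), a step of the same size as the earlier one, so a 4-chlorophenyl and a plain phenyl both stand apart from the 2-methoxyphenyl of compound 1. No measurement shown here explains either result.

Still open, as far as these compounds go, is whether methoxy set at another place on this ring would give the same number as in compound 1. Also open, from the compounds shown here alone, is whether a group other than chloro at this place, such as an amine or a carboxylic acid, would move the number beyond the scatter.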